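This account rests on a few compounds, and the source may have more. Where it says the series, first, only, none or still open, it means among the compounds named here.

In a functional assay on HepG2 cells (Homo sapiens) for inhibition, read by MTT assay, with a stated time of 72 h (on this read-out lower numbers stand for stronger inhibition and higher numbers for weaker inhibition), compound 1 `Clc1ccc(-c2nnc(SCCCN3CCN(c4nc5ccccc5o4)CC3)o2)cc1` gives 121000 nM and compound 2 `c1ccc(-c2nnc(SCCCN3CCN(c4nc5ccccc5o4)CC3)o2)cc1` gives 102000 nM, so the two lie within the scatter of each other. Still unmeasured is compound 3 `O=C(NCc1nnc(SCCCN2CCN(c3nc4ccccc4o3)CC2)o1)c1ccccc1`, which carries benzamidomethyl in place of phenyl on an aromatic carbon of the five-membered aromatic ring with 2 nitrogen and 1 oxygen (benzamidomethyl in place of phenyl on an aromatic carbon). Among the compounds with values here, the only measured step, a 1.2-fold lower number from compound 1 to compound 2 (0.07 log units; within the scatter), stays within the scatter, but it is hydrogen in place of chloro on an aromatic carbon, so it bears only loosely on replacing the whole phenyl. No measurement covers this change itself. On that thin basis, no step beyond the scatter is expected in this assay, in either direction. The expected size is a 1.1-fold lower number from compound 2 to compound 3 (0.05 log units; within the scatter). For compound 3 the estimated value is 90000 nM, with an expected range of 35000 nM to 220000 nM.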

Compound 3, half-maximal inhibitory concentration: 88900 nM
Compound 3: the middle estimate sits 1.0-fold (0.01 log units) above what was measured, and the stated range covers the measured number.
By their numbers in this assay, from the lowest: compounds 3, 2 and 1 (each within the scatter of the next).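

In this assay, benzamidomethyl in place of phenyl gives a 1.1-fold lower number from compound 2 to compound 3 (0.06 log units; within the scatter), and benzamidomethyl in place of 4-chlorophenyl gives a 1.4-fold lower number from compound 1 to compound 3 (0.13 log units; within the scatter). The earlier compounds shown here varied only a chloro on the phenyl, whereas here the whole group on the aromatic carbon changes, from phenyl to benzamidomethyl, with 1 hydrogen-bond donor and 1 hydrogen-bond acceptor entering, and still no step leaves the scatter. No supporting data offer an explanation for this flat picture.

Open, as far as these compounds go, is whether an amine or a carboxylic acid on this same carbon would produce a step beyond the scatter. From the compounds shown here alone, the shared core is constant across compounds 1, 2 and 3, so the effect of a change there in this assay also remains open.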